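The source may hold more compounds than are shown below. What is called first, only, known or untested is meant among the compounds shown, and "the series" means these compounds.

Compound 1 `O=c1oc2ccccc2cc1C1=NN(c2ccccc2)[C@@H](c2ccc(Cl)cc2Cl)C1`: 56.7%
Compound 2 `COc1cccc([C@H]2CC(c3cc4ccccc4oc3=O)=NN2c2ccccc2)c1`: 38.3%

In a functional assay on the whole organism (strain albino) for inhibition, with Rattus norvegicus as the target, read by paw edema, with stated times of 1 h and 2 h, at a dose of 200 mg/kg by the oral route (on this read-out higher numbers stand for more inhibition at the one dose given (going by the name of the read-out) and lower numbers for less inhibition), compound 2 stands lowest of the two numbers shown, with compound 1 as its nearest neighbour, higher by a step beyond the scatter. Compound 3 `O=c1oc2ccccc2cc1C1=NN(c2ccccc2)[C@@H](c2ccccc2[N+](=O)[O-])C1` is not yet measured. It differs from compound 2 by 2-nitrophenyl in place of 3-methoxyphenyl on a saturated ring carbon. For the measured compounds named here, no measured step exchanges 3-methoxyphenyl for 2-nitrophenyl; only the step of a number 18.4 percentage points lower from compound 1 to compound 2 (beyond the scatter) bears on the change, showing that the group on this saturated ring carbon shifts the read-out modestly. Compound 3 is therefore expected to rise by a number 9.7 percentage points higher from compound 2 to compound 3 (within the scatter), a step near the edge of the scatter. The estimate for compound 3 is 48%, within 32% to 62%.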

Compound 3, a percentage reported as inhibition, in the whole organism at one dose (the size of the read-out at that dose, not a potency): 24.7%
Beside the measured number, compound 3's estimate is 23.3 percentage points above it; the measured number lies below the stated range.
By their numbers in this assay, from the lowest: compound 3; then compound 2; then compound 1.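

In this assay, 2-nitrophenyl on this saturated ring carbon gives a number 13.6 percentage points lower from compound 2 to compound 3 (beyond the scatter) and a number 32 percentage points lower from compound 1 to compound 3 (beyond the scatter), so the read-out now falls in two steps beyond the scatter across the three aryl groups, with 2,4-dichlorophenyl highest and 2-nitrophenyl lowest. The size of the shift at this carbon thus reaches a large step, and a substituted phenyl here can lower the read-out further than 3-methoxyphenyl does. No measured evidence accounts for this order. Still open, as far as these compounds go, is how an unsubstituted phenyl, a 4-aminophenyl or a 4-carboxyphenyl on this carbon would compare.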